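Trifluoromethyl for fluoro across two cores

A few compounds are considered here, and "the series" means these few. Any claim that something is new, unique, unknown or untested is made for them only; others in the source may bear on it.

Compound 2 `CCN(CC)Cc1cc(Nc2nc3ccccc3n2Cc2ccc(F)cc2)ccc1O` and compound 1 `CCN(CC)Cc1cc(Nc2nc3ccccc3n2Cc2ccc(C(F)(F)F)cc2)ccc1O` share one core; compound 3 `CCN(CC)Cc1ccc(C)c(Nc2nc3ccccc3n2Cc2ccc(F)cc2)c1O` and compound 4 `CCN(CC)Cc1ccc(C)c(Nc2nc3ccccc3n2Cc2ccc(C(F)(F)F)cc2)c1O` share another, and the difference between the two cores is not broken down here. In an ADME assay on CHO cells (Cricetulus griseus) for inhibition, read by MTT assay (a lower number here means a stronger inhibitor, a higher number a weaker inhibitor), compound 2 gives 12000 nM and compound 1 gives 17500 nM. The change trifluoromethyl in place of fluoro on an aromatic carbon made a 1.5-fold higher number from compound 2 to compound 1 (0.16 log units; within the scatter). For compound 3 this assay reports only a limit, > 50000 nM, which is the limit of > 50000 nM in this assay, at which 1 of the 3 values shown sits. The change trifluoromethyl in place of fluoro on an aromatic carbon leads to compound 4; its place reads the same word for word as before, so it is the same change. The expected step that the limit leaves unreadable from compound 3 to compound 4 is small because a 1.5-fold higher number from compound 2 to compound 1 (0.16 log units; within the scatter) stayed within the scatter, and a limit is again expected because compound 3 already sits at the limit of > 50000 nM in this assay, at which 1 of the 3 values shown sits. Compound 4 is therefore expected at 75000 nM, estimated between 40000 nM and 150000 nM.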

Compound 4, half-maximal inhibitory concentration: 33900 nM
The estimate for compound 4 lay 2.2-fold (0.34 log units) above the measured number, and the stated range ends above it.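

In this assay, trifluoromethyl in place of fluoro was read on both cores, and on the second core it gave an at least 1.4-fold lower number from compound 3 to compound 4 (0.16 log units; that floor lies within the scatter). For compound 3 the value > 50000 nM is a limit of the assay and not a number. The two readings can be set side by side, but they do not show whether the change carries over from one core to the other with the same size: the same change on two cores in this assay, a 1.5-fold higher number (0.16 log units; within the scatter) from compound 2 to compound 1 and an at least 1.4-fold lower number (0.16 log units; that floor lies within the scatter) from compound 3 to compound 4; the limit leaves it open whether they differ

Still open, from the compounds shown here alone, is how a nitrile or a methoxy group in place of fluoro on the same aromatic carbon would read on either core. Also open, going by these compounds, is whether the same change behaves alike with another amine in place of the diethylamine.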